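Opening the piperidine side group of compound 2

The compounds below may be only part of what the source reports. "The series", "measured", "known", "first", "only" and "open" are said of these compounds alone.

Measured in a functional assay on A-375 cells (Homo sapiens) for inhibition, read by MTT assay, with a stated time of 5 days; on this read-out lower numbers stand for stronger inhibition and higher numbers for weaker inhibition:
- compound 1 `Nc1nccc(-c2sc(C3CCN(C4CC4)CC3)nc2-c2cccc(NS(=O)(=O)c3cc(F)ccc3F)c2F)n1`: 1.68 nM
- compound 2 `Nc1nccc(-c2sc(C3CCCNC3)nc2-c2cccc(NS(=O)(=O)c3cc(F)ccc3F)c2F)n1`: 44.1 nM

Of these two numbers, compound 2 has the higher, at 44.1 nM. Compound 3 `NCCCc1nc(-c2cccc(NS(=O)(=O)c3cc(F)ccc3F)c2F)c(-c2ccnc(N)n2)s1` has 3-aminopropyl in place of piperidin-3-yl on an aromatic carbon. Within the data shown here, only one measured step bears on this place: a 26-fold higher number from compound 1 to compound 2 (1.42 log units; beyond the scatter). That large step shows the group here can matter in this assay, but it involves a different exchange and cannot fix the size of this one. A moderate rise is therefore expected, though it may stay small. The expected change is a 2.3-fold higher number from compound 2 to compound 3 (0.36 log units; beyond the scatter). For compound 3 the estimate is 100 nM, with an expected range from 25 nM to 400 nM.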

Compound 3, half-maximal inhibitory concentration: 39.5 nM
Estimate against measurement, compound 3: 2.5-fold (0.40 log units) above; the range from low to high includes it.
By their numbers in this assay, from the lowest: compound 1; then compounds 3 and 2 (each within the scatter of the next).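

In this assay, replacing piperidin-3-yl with the open-chain 3-aminopropyl gave a 1.1-fold lower number from compound 2 to compound 3 (0.05 log units; within the scatter), so at this place the six-membered non-aromatic ring was not required to keep the level of compound 2. The exchange of 1-cyclopropylpiperidin-4-yl for 3-aminopropyl gave a 24-fold higher number from compound 1 to compound 3 (1.37 log units; beyond the scatter), so the open chain, like piperidin-3-yl, stays well apart from compound 1. No available evidence explains either step. The compounds shown leave open whether piperidin-4-yl without the cyclopropyl, or a cyclopropyl on the amine of 3-aminopropyl, would close that gap.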